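Removing the butyl chain: cytotoxicity outlook for compound 3

The source may hold more compounds than are shown below. What is called first, only, known or untested is meant among the compounds shown, and "the series" means these compounds.

Measured compounds:
- Compound 1 `FC(F)(F)c1nc(-c2cnc3ccc(-c4ccccc4)cc3c2)no1`: in a functional assay on RD cells (Homo sapiens) for inhibition, read by luminescence and ATP content, with a stated time of 72 h (on this read-out higher numbers stand for lower toxicity in this test and lower numbers for higher toxicity in this test), compound 1 gives only the limit > 22200 nM.
- Compound 2 `CCCCc1ccc(-c2ccc3ncc(-c4noc(CC)n4)cc3c2)cc1`: in this assay compound 2 gives only the limit > 7400 nM.

For the measured compounds named here, compound 2 thus stands on no number at all in this assay, only on a limit, and the single other value shown for this test is likewise a limit, as recorded in the limit of > 22200 nM in this assay, at which 1 of the 2 values shown sits, and (the limit of > 7400 nM in this assay, at which 1 of the 2 values shown sits). Compound 3 `CCc1nc(-c2cnc3ccc(-c4ccccc4)cc3c2)no1` is not yet measured. It differs from compound 2 by hydrogen in place of butyl on an aromatic carbon. Nothing measured here links this change to any shift in this assay, so no step beyond the usual scatter is expected, and the step that the limit leaves unreadable from compound 2 to compound 3 is expected to be essentially flat. Compound 3 is therefore estimated at 20000 nM in this assay, within a range of 6000 nM to 60000 nM, most likely again reported as a limit rather than a number.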

Compound 3, half-maximal cytotoxic concentration: > 7400 nM
Compound 3: a limit, no number (the forecaster's own chance of this, stated with the estimate: 80%); the middle value is on the limit's open side.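

For the compounds shown here, compound 3 gives only a limit in this assay, as do compound 1 and compound 2, so no step from compound 2 or compound 1 to compound 3 can be read. The compounds shown leave open whether hydrogen in place of butyl, or ethyl in place of trifluoromethyl, shifts the read-out in this assay at all.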